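Arylidene exchange on the shared core, compound 4 pending

The source may hold more compounds than are shown below. What is called first, only, known or untested is meant among the compounds shown, and "the series" means these compounds.

Measured so far, all in a functional assay on HepG2 cells (Homo sapiens) for antiproliferative activity, read by MTT assay; on this read-out lower numbers stand for stronger inhibition and higher numbers for weaker inhibition:
compound 1 `O=C1N=C(N2CCC[C@H]2C(=O)Nc2ccc3ncnc(Nc4cccc(Cl)c4)c3c2)S/C1=C/c1ccc(Br)s1` gives > 50000 nM; this value for compound 1 is a limit of the assay and not a number.
compound 2 `O=C1N=C(N2CCC[C@H]2C(=O)Nc2ccc3ncnc(Nc4cccc(Cl)c4)c3c2)S/C1=C/c1ccccc1Cl` gives 28100 nM.
compound 3 `O=C1N=C(N2CCC[C@H]2C(=O)Nc2ccc3ncnc(Nc4cccc(Cl)c4)c3c2)S/C1=C/c1cccnc1Cl` gives 6400 nM.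

Compound 2 holds the highest of the two numbers. Its nearest neighbour is compound 3, reached by a 4.4-fold lower number from compound 2 to compound 3 (0.64 log units; beyond the scatter). From the limit of compound 1 the step is an at least 1.7-fold lower number from compound 1 to compound 2 (0.25 log units; that floor lies within the scatter), and an at least 7.8-fold lower number from compound 1 to compound 3 (0.89 log units; beyond the scatter) is the larger of the two steps starting there.

The next compound, compound 4 `COc1ccccc1/C=C1/SC(N2CCC[C@H]2C(=O)Nc2ccc3ncnc(Nc4cccc(Cl)c4)c3c2)=NC1=O`, differs from compound 2 by methoxy in place of chloro on an aromatic carbon. Among the measured compounds shown here, no measured step bears on it directly: every measured step swaps the whole ring on the double-bonded chain carbon, whereas here the six-membered ring of carbon only is kept and one substituent on it is exchanged. The ring swaps moved the read-out by a 4.4-fold lower number from compound 2 to compound 3 (0.64 log units; beyond the scatter) and by an at least 7.8-fold lower number from compound 1 to compound 3 (0.89 log units; beyond the scatter), but also by no more than an at least 1.7-fold lower number from compound 1 to compound 2 (0.25 log units; that floor lies within the scatter), which sits within the scatter. For the measured compounds named here, with no closer precedent, the expected step is a 1.0-fold lower number from compound 2 to compound 4 (0.00 log units; within the scatter), i.e. none beyond the scatter. Compound 4 is thus estimated at 28000 nM, within 9000 nM to 90000 nM; since the limit of > 50000 nM in this assay, at which 1 of the 3 values shown sits, shows the assay reports limits in this region, a limit rather than a number remains possible for compound 4.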

Compound 4, half-maximal inhibitory concentration: 22100 nM
The estimate for compound 4 lay 1.3-fold (0.10 log units) above the measured number; measured number inside the range.
By their numbers in this assay, from the lowest: compound 3; then compounds 4 and 2 (each within the scatter of the next). At a limit, above all of these: compound 1.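

In this assay, among the compounds shown here, the exchange of chloro for methoxy on an aromatic carbon ortho to a large group is the first change that keeps the six-membered aromatic ring of carbon only, and it gives a 1.3-fold lower number from compound 2 to compound 4 (0.10 log units; within the scatter), so compound 2 and compound 4 read alike and the larger methoxy, with its hydrogen-bond acceptor, leaves no mark beyond the scatter at this place. The separation of compound 3 holds against the new 2-methoxyphenyl compound as well, at a 3.5-fold higher number from compound 3 to compound 4 (0.54 log units; beyond the scatter), so among these compounds the clearest difference goes with the whole-ring swap to 2-chloropyridin-3-yl and not with the exchange of this one substituent. The step of an at least 2.2-fold lower number from compound 1 to compound 4 (0.35 log units; beyond the scatter) gives only a floor, as the entry for compound 1 is a limit of the assay and not a number: the limit of > 50000 nM in this assay, at which 1 of the 4 values shown sits.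

From the compounds shown here alone, whether an amine or a carboxylic acid on the same aromatic carbon would also read like compound 2 stays open. Also open, going by these compounds, is whether methoxy in place of chloro on the 2-chloropyridin-3-yl ring of compound 3 would leave the read-out as unmoved as it does on the 2-chlorophenyl ring.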